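The compounds below may be only part of what the source reports. "The series", "measured", "known", "first", "only" and "open" are said of these compounds alone.

Measured so far:
compound 1, `CCN(CC)CCCCN/C(=N\c1ccnc2cc(Cl)ccc12)C(C)C` — 0.917 h
compound 2, `Clc1ccc2c(N(CCCN3CCCCC3)/C(=N/CCCN3CCCCC3)c3ccccc3)ccnc2c1` — 0.517 h

Two compounds have numbers in an ADME assay (liver) for metabolic stability, with Liver microsome (Homo sapiens) as the target, read by LC-MS, using microsomes, tested at 1 uM; on this read-out higher numbers stand for a longer-lived compound and lower numbers for a shorter-lived compound. Compound 1, `CCN(CC)CCCCN/C(=N\c1ccnc2cc(Cl)ccc12)C(C)C`, gives 0.917 h there. Compound 2, `Clc1ccc2c(N(CCCN3CCCCC3)/C(=N/CCCN3CCCCC3)c3ccccc3)ccnc2c1`, gives 0.517 h in this assay. Compound 1 stands at the top of the two numbers, but the gap to compound 2 is within the usual scatter of repeated runs, so the two are not separated and no order between them is claimed.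

Compound 3, `CC(C)/C(=N/c1ccnc2cc(Cl)ccc12)NCCCN1CCCCC1`, has not been measured in this assay. It differs from compound 1 in one place: piperidin-1-yl in place of (diethylamino)methyl on a saturated chain carbon, three bonds along the chain from an amine nitrogen. Both groups carry the same count of heavy atoms and the same single acceptor, and the chain from the amine nitrogen to the shared core is unchanged.

Going by the values given here, no measured pair in this set shows the effect of such a change, so there is no step to lean on. The expectation for compound 3 is a step from compound 1 of no more than the scatter, a 1.2-fold lower number from compound 1 to compound 3 (0.09 log units; within the scatter), with no firm direction. Compound 3 is expected to give about 0.75 h in this assay, in a range from 0.35 h to 1.6 h.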

Compound 3, half-life: 0.483 h
For compound 3 the middle estimate is 1.6-fold (0.19 log units) above the measured one, within the range that was stated.
By their numbers in this assay, from the lowest: compounds 3, 2 and 1 (each within the scatter of the next).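

Going by these compounds alone, this is the first readable step at this place: in this assay, piperidin-1-yl in place of (diethylamino)methyl on a saturated chain carbon, three bonds along the chain from an amine nitrogen, gives a 1.9-fold lower number from compound 1 to compound 3 (0.28 log units; within the scatter). Closing the open diethylamino end into a six-membered non-aromatic ring, with the heavy-atom count and acceptor count unchanged, therefore does not separate the two compounds on this read-out, and this single pair supports no order between them. No available evidence bears on why the step has this size, so the result stands only as a description of this one pair.

The compounds shown leave open whether a pyrrolidin-1-yl or morpholin-4-yl group at this place, or a longer chain carrying the piperidin-1-yl group, would give a step beyond the scatter in this assay. Compound 2 differs from compound 1 and compound 3 in more than one place, so it leaves open whether this near-silent exchange would hold on a different amidine substituent, such as the phenyl group it carries.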